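This account rests on a few compounds, and the source may have more. Where it says the series, first, only, none or still open, it means among the compounds named here.

In a functional assay on A-375 cells (Homo sapiens) for inhibition, read by CCK-8 assay, with a stated time of 72 h, tested at 8 uM (on this read-out lower numbers stand for less inhibition of growth and higher numbers for more inhibition of growth at the one concentration tested), compound 3 `Cc1ccc(SCc2ccc(/C=C/C(=O)Nc3ccccc3N)cc2)cc1` gives 31.2%, the second highest of three numbers. Compound 1 `COc1ccc(SCc2ccc(/C=C/C(=O)Nc3ccccc3N)cc2)cc1OC` stands higher at 46.4%, and compound 2 `Nc1ccccc1NC(=O)/C=C/c1ccc(CSc2ccc(C(F)(F)F)cn2)cc1` lower at 3.96%. Compound 4 `Nc1ccccc1NC(=O)/C=C/c1ccc(CSc2ccc(F)cc2)cc1` has not yet been measured. Its structure differs from that of compound 3 by one change: fluoro in place of methyl on an aromatic carbon, with fluoro in place of methyl on an aromatic carbon, para to a large group.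

All three measured steps alter the group on the sulfur, and none exchanges methyl for fluoro. Replacing 3,4-dimethoxyphenyl with 4-methylphenyl gives a modest step, a number 15.2 percentage points lower from compound 1 to compound 3 (beyond the scatter). The large step, a number 42.4 percentage points lower from compound 1 to compound 2 (beyond the scatter), comes with 5-(trifluoromethyl)pyridin-2-yl, and the reverse comparison gives a number 27.2 percentage points higher from compound 2 to compound 3 (beyond the scatter). Compound 4 keeps a substituted phenyl on the sulfur, so a small change is expected in this assay rather than a drop of that large size. The expected result is a number 5.2 percentage points lower from compound 3 to compound 4 (within the scatter), slightly downward and probably within the scatter. The estimate for compound 4 is 26%, with an expected range of 10% to 42%.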

Compound 4, percent growth inhibition at one concentration: 24.6%
Beside the measured number, compound 4's estimate is 1.4 percentage points above it; the range from low to high includes it.
By their numbers in this assay, from the lowest: compound 2; then compounds 4 and 3 (each within the scatter of the next); then compound 1.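

In this assay the exchange of methyl for fluoro on an aromatic carbon, para to a large group, gives a number 6.6 percentage points lower from compound 3 to compound 4 (within the scatter) and so does not separate the two groups at this position. The 4-fluorophenyl group also stays apart from the other two groups on the sulfur, with a number 20.6 percentage points higher from compound 2 to compound 4 (beyond the scatter) and a number 21.8 percentage points lower from compound 1 to compound 4 (beyond the scatter), so the gaps seen with 4-methylphenyl are not peculiar to methyl. No evidence is available on what lies behind these numbers.

The compounds shown leave open whether an amine or a carboxylic acid at this same place would stay level with methyl and fluoro. They also leave open whether a 4-(trifluoromethyl)phenyl group on the sulfur would stand nearer to compound 4 or to compound 2.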